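Benzamide para-substituent: ethyl against methoxy in a ROCK1 series

A few compounds are considered here, and "the series" means these few. Any claim that something is new, unique, unknown or untested is made for them only; others in the source may bear on it.

Measured compounds in an assay on isolated protein for inhibition of Rho-associated protein kinase 1 (Homo sapiens), read by scintillation counting, radiometric assay and 33P incorporation, with a stated time of 40 min, in the presence of a further agent that is not named here; a lower number here means a stronger inhibitor, a higher number a weaker inhibitor:
compound 1 `CN(C)c1ccc(C(=O)Nc2cccc(NC(=O)COc3ccc4c(c3)CCC(=O)N4)c2)cc1`: > 10000 nM
compound 2 `COc1ccc(OCC(=O)Nc2cccc(NC(=O)c3ccc(N(C)C)cc3)c2)cc1F`: 1820 nM
compound 3 `CCc1ccc(C(=O)Nc2cccc(NC(=O)COc3ccc4c(=O)ccoc4c3)c2)cc1`: 235 nM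

The value of compound 1 is a limit of this assay, not a number (the limit of > 10000 nM in this assay, at which 1 of the 3 values shown sits). Of the two numbers given, compound 3 holds the lower one, and compound 2 sits at the higher one, the gap being beyond the scatter.

Compound 4 `COc1ccc(C(=O)Nc2cccc(NC(=O)COc3ccc4c(=O)ccoc4c3)c2)cc1` has not yet been measured in this assay. It differs from compound 3 in one place only: methoxy in place of ethyl on an aromatic carbon. Among the measured compounds shown here, the only step measured between compounds that differ in one place is an at least 5.4-fold lower number from compound 1 to compound 2 (0.73 log units; beyond the scatter), which concerns the oxygen on a saturated carbon at the other end of the shared core, not the aromatic carbon changed here. Compounds 1 and 2 both carry a dimethylamino group at that aromatic position and differ from compound 3 in more than one place, so their two values show nothing that can be read as a single step to the change from ethyl to methoxy.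

For the measured compounds named here, with no measured step bearing on this position, the expectation is a change within the scatter, in no particular direction: a 1.3-fold higher number from compound 3 to compound 4 (0.11 log units; within the scatter) is the step the estimate implies. For compound 4 the estimate in this assay is 300 nM, with a range from 100 nM to 1000 nM.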

Compound 4, half-maximal inhibitory concentration: 18 nM
Compound 4: the middle estimate sits 17-fold (1.22 log units) above what was measured, and the stated range ends above it.
By their numbers in this assay, from the lowest: compound 4; then compound 3; then compound 2. At a limit, above all of these: compound 1.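

In this assay the aromatic carbon para to a large group proves sensitive: methoxy in place of ethyl gives a 13-fold lower number from compound 3 to compound 4 (1.12 log units; beyond the scatter) even though the count of heavy atoms stays the same and the entering group adds 1 hydrogen-bond acceptor. Among the compounds shown here, this is the only step that reads this position directly, as compound 1 and compound 2 both carry dimethylamino there and differ from compound 3 in more than one place, while an at least 5.4-fold lower number from compound 1 to compound 2 (0.73 log units; beyond the scatter) concerns the other end of the shared core. No measurement shown here accounts for the size of this step.

Open, going by these compounds, is how a hydroxyl, a chlorine or an ethoxy at this position would compare with methoxy on the same shared core, which would show whether the step follows the oxygen or is particular to the methoxy group. Also open, on these data alone, is whether the same change of ethyl to methoxy would give a step of similar size with the other end of the shared core carrying the groups found in compound 1 or compound 2.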